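This account rests on a few compounds, and the source may have more. Where it says the series, first, only, none or still open, it means among the compounds named here.

Measured compounds:
compound 1, `COc1ccc(-c2nc3c(c(-c4ccccc4)nn3-c3ccccc3)c(-c3ccc(O)cc3)c2C#N)cc1`: 6700 nM
compound 2, `COc1ccc(-c2c(C#N)c(-c3ccccc3)nc3c2c(-c2ccccc2)nn3-c2ccccc2)cc1OC`: > 25000 nM

In a functional assay on CCRF-CEM cells (Homo sapiens) for antiproliferative activity, read by resazurin assay, with a stated time of 72 h (on this read-out higher numbers stand for weaker inhibition and lower numbers for stronger inhibition), compound 1 gives 6700 nM, the only numerical value among the two results shown. Compound 2 is reported only as a limit of the assay, > 25000 nM, which is the limit of > 25000 nM in this assay, at which 1 of the 2 values shown sits. For the measured compounds named here, no two measured compounds differ in a single place, so no measured step is available; the two results say only that compound 1 sits at a measurable concentration while compound 2 does not. Compound 3, `Cc1ccc(-c2nc3c(c(-c4ccccc4)nn3-c3ccccc3)c(-c3ccc(O)cc3)c2C#N)cc1`, has not yet been measured. It differs from compound 1 by methyl in place of methoxy on an aromatic carbon, para to a large group, or, cut one bond further out, 4-methoxyphenyl to 4-methylphenyl. Going by the values given here, with no measured step to lean on, the change is expected to be modest and could run in either direction. The step is estimated as a 1.2-fold higher number from compound 1 to compound 3 (0.08 log units; within the scatter), not clearly beyond the usual scatter. Near compound 1, compound 3 is therefore expected to give 8000 nM, with a range from 3500 nM to 20000 nM.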

Compound 3, half-maximal inhibitory concentration: 13400 nM
For compound 3 the middle estimate is 1.7-fold (0.22 log units) below the measured one, within the range that was stated.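

In this assay, for the compounds shown here, putting methyl in place of methoxy on an aromatic carbon, para to a large group, gives the first measured step: a 2.0-fold higher number from compound 1 to compound 3 (0.30 log units; within the scatter). The exchange removes a group counted with one hydrogen-bond acceptor and puts in one counted with none, and this single pair shows no difference beyond the usual scatter of the assay, so the oxygen of the methoxy group is not shown to be needed at this position on this read-out. Compound 3, like compound 1, also gives a measurable number rather than a limit, so this change does not take the core of compound 1 to the assay's limit: the limit of > 25000 nM in this assay, at which 1 of the 3 values shown sits.

What the compounds shown leave open is whether an amine, a chlorine atom or a longer chain such as ethoxy at this same position would read any differently from methoxy or methyl, since one pair spans only a narrow range of groups. As far as these compounds go, compound 2 differs from compound 1 in more than one place, so which of its differences goes with its limit also stays open.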